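A few compounds are considered here, and "the series" means these few. Any claim that something is new, unique, unknown or untested is made for them only; others in the source may bear on it.

Measured so far:
compound 1, `CSc1cnc2ccccc2c1SCC#CCOC(=O)c1ccccc1`, 22.2 ug/mL
compound 2, `CSc1cnc2ccccc2c1[Se]CC#CCOC(=O)/C=C/c1ccccc1`, 17.8 ug/mL

Both compounds were tested in a functional assay on CCRF-CEM cells (Homo sapiens) for antiproliferative activity, with a stated time of 72 h; a lower number here means a stronger inhibitor, a higher number a weaker inhibitor. Compound 1 gives 22.2 ug/mL in this assay, and compound 2 gives 17.8 ug/mL. The gap between them is within the usual scatter of such measurements, so the two numbers cannot be told apart; compound 2 merely sits at the end of this pair from which the next step is taken.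

Compound 3, `CSc1cnc2ccccc2c1[Se]CC#CCOC(=O)c1ccccc1`, has not yet been measured. It differs from compound 2 in one place: phenyl in place of 2-phenylethenyl on a carbonyl carbon. Compound 3 shares this ester with compound 1 and shares the rest of its structure with compound 2.

Among the compounds with values here, no measured step exists for this kind of change in the present set, so there is no direct guide to its size. Given that compound 1 and compound 2 sit within the scatter of each other, the step from compound 2 to compound 3 is expected to stay within the scatter as well, with no change in direction that can be foreseen. Compound 3 is therefore estimated to give 20 ug/mL in this assay, in the range 10 ug/mL to 40 ug/mL, corresponding to an expected step of a 1.1-fold higher number from compound 2 to compound 3 (0.05 log units; within the scatter).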

Compound 3, concentration for 50% inhibition: 1.9 ug/mL
Estimate against measurement, compound 3: 11-fold (1.02 log units) above; the whole stated range lies above it.
By their numbers in this assay, from the lowest: compound 3; then compounds 2 and 1 (each within the scatter of the next).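

With selenium held in place, phenyl in place of 2-phenylethenyl on a carbonyl carbon gives a 9.4-fold lower number from compound 2 to compound 3 (0.97 log units; beyond the scatter) in this assay, so this end of the molecule is far from neutral: removing the double bond outside the aromatic ring and two carbon atoms is enough to move the number beyond the scatter. The phenyl ester does not bring this low number on its own, since compound 3 gives 1.9 ug/mL, whereas with the same ester but sulfur in place of the selenium of compound 3, compound 1 gives 22.2 ug/mL. Nothing available here explains why the change has this size.

The compounds shown leave open whether the double bond or the added length matters more, which a saturated 2-phenylethyl group on the carbonyl carbon could help separate. They also leave open whether the aromatic ring itself is needed at that place, as a simple methyl group there would show, and whether the same step would appear with sulfur instead of selenium.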